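The source may report more compounds than this note shows. Statements on the series, on what has been measured and on what is new or still open speak of the compounds shown alone.

Measured compounds in a toxicity assay on MDCK cells (Canis lupus familiaris) for cytotoxicity, read by crystal violet staining, with a stated time of 48 h; on this read-out lower numbers stand for higher toxicity in this test and higher numbers for lower toxicity in this test:
- compound 1 `Cc1ccc2cc(CN(Cc3ccc(F)cc3)Cc3ccc(C(F)(F)F)cc3)c(=O)[nH]c2c1`: > 33000 nM, a limit of this assay
- compound 2 `Cc1ccc2[nH]c(=O)c(CN(Cc3ccc(F)cc3)Cc3cccc4ccccc34)cc2c1`: > 5000 nM, a limit of this assay
- compound 3 `Cc1ccc2[nH]c(=O)c(CN(Cc3ccc(OCC(=O)O)cc3)Cc3ccc(C(C)(C)C)cc3)cc2c1`: > 10000 nM, a limit of this assay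

None of the three values is a number; each is a limit at which no half-maximal cytotoxic concentration was reached. Compound 3 stands at one of these limits, that of the limit of > 10000 nM in this assay, at which 1 of the 3 values shown sits. Compound 1 stands at a different limit, that of the limit of > 33000 nM in this assay, at which 1 of the 3 values shown sits. Compound 2 stands at a third, that of the limit of > 5000 nM in this assay, at which 1 of the 3 values shown sits. Across the three compounds, the shared core carries varied pairs of benzyl groups on the amine, and no cytotoxicity was resolved in any case.

Compound 4 `Cc1ccc2[nH]c(=O)c(CN(Cc3ccc(OC(F)(F)F)cc3)Cc3ccc(C(C)(C)C)cc3)cc2c1` is not yet measured in this assay. It differs from compound 3 by trifluoromethyl in place of carboxymethyl on an oxygen on an aromatic ring. Going by the values given here, no measured pair in the set differs in one place, so no measured step sets a scale; the only guidance is that all three measured compounds sit at a limit. The step from compound 3 to compound 4 is therefore expected to stay within the scatter, with no direction beyond it, and the expected change is a step that the limit leaves unreadable from compound 3 to compound 4. The estimate for compound 4 in this assay is 20000 nM, with a range from 5000 nM to 80000 nM, and the result is expected most likely to be reported again as a limit.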

Compound 4, half-maximal cytotoxic concentration: > 5000 nM
Compound 4: only a limit was reported (the forecaster's own chance of this, stated with the estimate: 70%); the middle value lies beyond the limit too.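

No step can be read between compound 3 and compound 4 in this assay; both results are limits, not numbers. The compounds shown leave open whether trifluoromethyl in place of carboxymethyl on an oxygen on an aromatic ring alters the half-maximal cytotoxic concentration, and at what concentration any of the four compounds would reach it.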